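Methyl and Nitrile Changes on a Shared Core

The source may report more compounds than this note shows. Statements on the series, on what has been measured and on what is new or still open speak of the compounds shown alone.

Compound 1, `FC(F)(F)c1ccc(CN2CCN(Cc3cc(-c4ccc(OCc5ccccc5)cc4)on3)CC2)cc1`, in a functional assay on Huh-7 cells (Homo sapiens) for antiproliferative activity, read by sulforhodamine B assay, with a stated time of 72 h (a lower number here means a stronger inhibitor, a higher number a weaker inhibitor), gives 1700 nM.
Compound 2, `Cc1cccc(COc2ccc(-c3cc(CN4CCN(Cc5ccc(C(F)(F)F)cc5)CC4)no3)cc2)c1`, in this assay gives 5000 nM.
Compound 3, `N#Cc1cccc(COc2ccc(-c3cc(CN4CCN(Cc5ccc(C(F)(F)F)cc5)CC4)no3)cc2)c1`, in this assay gives 100 nM.

Compound 3 has the lowest of the three numbers; the step to it from compound 1 is a 17-fold lower number from compound 1 to compound 3 (1.23 log units; beyond the scatter) and from compound 2 is a 50-fold lower number from compound 2 to compound 3 (1.70 log units; beyond the scatter). The cores of compound 1 and compound 3 differ by cyano in place of hydrogen on an aromatic carbon.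

The unmeasured compound 4, `Cc1cc(-c2cc(CN3CCN(Cc4ccc(C(F)(F)F)cc4)CC3)no2)ccc1OCc1cccc(C#N)c1`, differs from compound 3 by methyl in place of hydrogen on an aromatic carbon. A change of the same kind has already been measured once, from compound 1 to compound 2: methyl in place of hydrogen on an aromatic carbon, and it gave a 2.9-fold higher number from compound 1 to compound 2 (0.47 log units; beyond the scatter). The two places are not the same, though. In compound 4 the methyl sits ortho to a (3-cyanobenzyl)oxy group and meta to a large group, while in compound 2 it sits only meta to a large group.

Resting on that single earlier step, a modest weakening is expected for compound 4 in this assay, a step of a 2.2-fold higher number from compound 3 to compound 4 (0.34 log units; beyond the scatter), because the earlier methyl gave a 2.9-fold higher number from compound 1 to compound 2 (0.47 log units; beyond the scatter). The estimated value for compound 4 is 220 nM, expected to lie between 80 nM and 600 nM.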

Compound 4, half-maximal inhibitory concentration: 600 nM
Compound 4: the middle estimate sits 2.7-fold (0.44 log units) below what was measured; the measured number falls inside the stated range.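

In this assay, adding the methyl gives a 6.0-fold higher number from compound 3 to compound 4 (0.78 log units; beyond the scatter), so this kind of change moved the number in the same direction on both cores, and the two steps do not differ by more than repeated measurements could explain: the same change on two cores in this assay, a 2.9-fold higher number (0.47 log units; beyond the scatter) from compound 1 to compound 2 and a 6.0-fold higher number (0.78 log units; beyond the scatter) from compound 3 to compound 4, 2.0-fold (0.31 log units) apart, within the scatter of two such steps. For these two pairs, then, the weakening carried over from one core to another, both in direction and, within the scatter, in size. This is not yet a rule for the series, since it rests on just two pairs, the methyl does not sit at the same place in them, and nothing here tells why the number rises.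

The compounds shown leave open whether another small group, such as a chlorine atom or a methoxy group, would move the number in the same way at the place the methyl holds in compound 4. They also leave open whether a methyl at that place would give a similar step on the core of compound 1, which has no nitrile.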